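A few compounds are considered here, and "the series" means these few. Any claim that something is new, unique, unknown or untested is made for them only; others in the source may bear on it.

Measured compounds:
- compound 1, `COCc1nnc(N2CCC(c3ccc(F)cc3Cl)CC2)n1-c1ccc(OC)nc1`: 10 nM
- compound 2, `CCOCc1nnc(N2C[C@@H]3C[C@]3(c3ccc(F)cc3Cl)C2)n1-c1ccc(OC)nc1`: 9.3 nM

The series is followed in a functional assay on HEK293 cells for antagonist activity at Oxytocin receptor (Homo sapiens), read by calcium flux, with a stated time of 10 min, in the presence of a further agent that is not named here; a higher number here means a weaker inhibitor, a lower number a stronger inhibitor. Compound 1 gives 10 nM in this assay. Compound 2 gives 9.3 nM in this assay, and the two numbers sit within the scatter of one another, so no order between compound 1 and compound 2 can be read from them. No step between measured compounds that differ in one place is shown; what can be said is only that the two measured structures, with their different ether chains and saturated ring systems, reach the same region of potency.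

The next compound, compound 3, `COc1ccc(-n2c(CO[C@H]3CCOC3)nnc2N2C[C@@H]3C[C@]3(c3ccc(F)cc3Cl)C2)cn1`, departs from compound 2 by one change: oxolan-3-yl in place of ethyl on an oxygen on a saturated carbon. Oxolan-3-yl in place of ethyl on an oxygen on a saturated carbon is the whole of the difference.

With two compounds at the same level, the expectation is that the step from compound 2 to compound 3 in this assay stays within the scatter, a 1.2-fold higher number from compound 2 to compound 3 (0.07 log units; within the scatter). Compound 3 is therefore estimated at 11 nM in this assay, with a range from 4 nM to 30 nM.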

Compound 3, half-maximal inhibitory concentration: 184 nM
The estimate for compound 3 lay 17-fold (1.22 log units) below the measured number; the measured number lies above the stated range.
By their numbers in this assay, from the lowest: compounds 2 and 1 (each within the scatter of the next); then compound 3.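

In this assay, going by these compounds alone, oxolan-3-yl in place of ethyl on an oxygen on a saturated carbon gives a 20-fold higher number from compound 2 to compound 3 (1.30 log units; beyond the scatter), the first single-place step and a large one, so the group on this ether oxygen is not a free choice, whereas the earlier pair, which differs in more than one place, could not isolate this position. The change has several parts: 2 heavy atoms and no ring leave, while 5 heavy atoms enter, with a five-membered non-aromatic ring, 1 hydrogen-bond acceptor and 1 defined stereocentre, so this single step cannot assign the rise in the number to any one of these features. No measurement at hand explains the rise.

Open, from the compounds shown here alone, is which of these features carries the step: cyclopentyl on the same oxygen would keep a five-membered ring without the ring oxygen, while a longer chain such as n-butyl would add carbon without any ring. Also open, going by these compounds, is whether the opposite configuration at the oxolan-3-yl stereocentre reads the same, and whether this result carries over to the core of compound 1.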